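Ester-to-acid step on two fluorenyl cores, receptor displacement

The source may hold more compounds than are shown below. What is called first, only, known or untested is meant among the compounds shown, and "the series" means these compounds.

Measured so far, in an assay on cells for displacement of a labelled ligand from Orexin/Hypocretin receptor type 1 (Homo sapiens), read by scintillation counting, with stated times of 10 min and 90 min, tested at 10 uM; a lower number here means less inhibition, a higher number more inhibition at the concentration tested (going by the name of the read-out):
compound 1 `COC(=O)c1cccc2c(C(=O)c3ccccc3)cc(C(=O)c3ccc(C(Cl)(Cl)Cl)cc3)c-2c1`: 10.4%
compound 2 `O=C(O)c1cccc2c(C(=O)c3ccccc3)cc(C(=O)c3ccc(C(Cl)(Cl)Cl)cc3)c-2c1`: 19.9%
compound 3 `COC(=O)c1ccc2c(C=O)cc(-c3ccccc3)c-2cc1`: 8.5%

Compound 1 and compound 2 share one core and differ by hydrogen in place of methyl on an oxygen next to a carbonyl group. The step of a number 9.5 percentage points higher from compound 1 to compound 2 (within the scatter) is small and sits within the scatter of repeated runs, so the two values cannot be ordered.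

Compound 3 carries a different core; the difference between the core of compound 1 and the core of compound 3 is not broken down here. Compound 3 and compound 1 give values within the scatter of each other; compound 2 stands beyond the scatter above compound 3.

Compound 4 `O=Cc1cc(-c2ccccc2)c2ccc(C(=O)O)ccc1-2` is not yet measured. It differs from compound 3 by hydrogen in place of methyl on an oxygen next to a carbonyl group, the same change as made from compound 1 to compound 2, on the same kind of place. Going by the values given here, the only guide is the step of a number 9.5 percentage points higher from compound 1 to compound 2 (within the scatter), which was within the scatter. Among the compounds with values here, on that basis the expected step is a number 6.5 percentage points higher from compound 3 to compound 4 (within the scatter), with wide uncertainty because the one precedent is a single pair on another core. The estimate for compound 4 in this assay is 15%, expected to fall between 2% and 28%.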

Compound 4, a percentage reported as inhibition, at one concentration (the size of the read-out at that concentration, not a potency): 16.2%
Compound 4: middle estimate off by 1.2 percentage points, on the low side; low and high end bracket the measured number.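

In this assay, hydrogen in place of methyl on an oxygen next to a carbonyl group gives a number 7.7 percentage points higher from compound 3 to compound 4 (within the scatter), and this step agrees with the one seen on the other core: the same change on two cores in this assay, a number 9.5 percentage points higher (within the scatter) from compound 1 to compound 2 and a number 7.7 percentage points higher (within the scatter) from compound 3 to compound 4, 1.8 percentage points apart, within the scatter of two such steps

The two cores therefore show no measurable difference in how this change reads, and the earlier step is a fair guide to the size of the later one. This does not show that the change has a real effect on either core, as each step lies within the scatter on its own, and two pairs set no rule for any further core.

The compounds shown leave open how a primary amide, or a longer chain such as an ethyl ester in place of the methoxycarbonyl, would read on these cores. They also leave open whether any compound in the series has a measurable potency, as the read-out comes from a single tested concentration.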